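Fluorine on the anilide ring of a thiadiazole acid

A few compounds are considered here, and "the series" means these few. Any claim that something is new, unique, unknown or untested is made for them only; others in the source may bear on it.

Measured so far:
compound 1 `O=C(O)CCc1nnc(C(=O)Nc2cccc(-c3ccc(F)cc3)c2)s1` gives 1280 nM in a functional assay on CHO cells for agonist activity at Free fatty acid receptor 1 (Homo sapiens), read by calcium flux; a higher number here means that more compound is needed for the effect, a lower number that less compound is needed
compound 2 `O=C(O)CCc1nnc(C(=O)Nc2ccc(OCc3ccccc3)cc2)s1` gives 17900 nM
compound 3 `O=C(O)CCc1ccc(OCc2nnc(C(=O)Nc3ccccc3)s2)cc1` gives 1060 nM

Compound 3 has the lowest number of the three. Its nearest neighbour is compound 1, whose value lies within the scatter of repeated measurements, so the two cannot be told apart. Compound 2 stands far above both, beyond the scatter.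

Compound 4 `O=C(O)CCc1ccc(OCc2nnc(C(=O)Nc3ccc(F)cc3)s2)cc1` is compound 3 with one change: fluoro in place of hydrogen on an aromatic carbon. For the measured compounds named here, no measured pair in this set shows this exact change on its own, so there is no step to lean on. Compound 1 also carries a fluoro group on an aromatic ring and sits within the scatter of compound 3, which gives no hint of a large shift in either direction. A single fluorine at this place is expected to move this assay little, if at all, with the expected step from compound 3 to compound 4 being a 1.2-fold lower number from compound 3 to compound 4 (0.10 log units; within the scatter). Compound 4 is therefore estimated at 850 nM, with a likely range from 300 nM to 2500 nM.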

Compound 4, half-maximal effective concentration: 6640 nM
Estimate against measurement, compound 4: 7.8-fold (0.89 log units) below; measured number outside the range, above it.
By their numbers in this assay, from the lowest: compounds 3 and 1 (each within the scatter of the next); then compound 4; then compound 2.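

For the compounds shown here, changing phenyl to 4-fluorophenyl brings a 6.3-fold higher number from compound 3 to compound 4 (0.80 log units; beyond the scatter) in this assay and is the first single-place change in this set, as no earlier pair differed in only one place. It shows that this position is not indifferent: a single added fluorine atom, with no ring and no net charge, is enough to move the number beyond the usual scatter, and towards needing more compound. Nothing measured here gives a reason for this step.

On these data alone, whether any added group at this place raises the number, or this is particular to fluoro, stays open, and a chloro, methyl or methoxy group there would begin to separate the two. This single pair also leaves open whether the same change would act alike on the core of compound 2.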